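The source may report more compounds than this note shows. Statements on the series, on what has been measured and on what is new or still open speak of the compounds shown alone.

Measured so far:
compound 2 `CC(C)C(c1cnc(N)s1)c1ccc(-c2ccc3cccc(F)c3c2)[nH]c1=O` gives 0.0983 h in an ADME assay on microsomes from liver (Rattus norvegicus) for metabolic stability; a higher number here means that the compound lasts longer, a lower number that the compound disappears faster
compound 1 `CCn1ncc2c(F)cc(-c3ccc(C(CC)(CC)c4nnc[nH]4)c(=O)[nH]3)cc21` gives > 3 h, which is a limit of this assay and not a number

Compound 2 holds the only plain number shown; in this assay compound 2 lasts 0.0983 h. For compound 1 the reading in this assay is only a limit, > 3 h. Compound 3 `CC(C)C(/C=C1\CCNC1=O)c1ccc(-c2ccc3cccc(F)c3c2)[nH]c1=O` has not yet been measured. It differs from compound 2 in one place: a group of 7 heavy atoms (5 carbon, 1 nitrogen, 1 oxygen; one five-membered non-aromatic ring with 1 hetero atom) in place of a group of 6 heavy atoms (3 carbon, 2 nitrogen, 1 sulfur; one five-membered aromatic ring with 2 hetero atoms), on a saturated chain carbon bound to an aromatic carbon and a saturated chain carbon. Within the data shown here, no measured pair shows what such a change does here, so the step from compound 2 to compound 3 is expected to stay within the usual scatter, a 1.2-fold higher number from compound 2 to compound 3 (0.09 log units; within the scatter). Compound 3 is therefore estimated at 0.12 h, between 0.04 h and 0.4 h.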

Compound 3, half-life: 0.345 h
Compound 3: middle estimate off by 2.9-fold (0.46 log units), on the low side; measured number inside the range.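

In this assay, among these compounds, the change on the saturated chain carbon bound to an aromatic carbon and a saturated chain carbon gives a 3.5-fold higher number from compound 2 to compound 3 (0.55 log units; beyond the scatter) and is the first measured step at this place. It shows that the group held there can move this read-out beyond the usual scatter, though only modestly, and that the 2-amino-1,3-thiazol-5-yl group can be replaced by a non-aromatic ring. Nothing shown here explains the rise. Whether the ring or its double bonds account for the rise stays open. So does what a simple amine or a piperidine ring on the same carbon would do.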